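The source may hold more compounds than are shown below. What is called first, only, known or untested is meant among the compounds shown, and "the series" means these compounds.

Working notes on the series. For the measured compounds named here, compound 1 (`CC(=O)Nc1ccc(/C=N/NC(=O)c2no[n+]([O-])c2C)cc1`) gives 235000 nM in an ADME assay on J774.1 cells (Mus musculus) for cytotoxicity, read by MTT assay, with a stated time of 48 h (a lower number here means a stronger inhibitor, a higher number a weaker inhibitor), and holds the only true number in the set. Compound 2 (`COc1ccc(/C=N/NC(=O)c2no[n+]([O-])c2C)cc1OC`) reads > 400000 nM as a limit of the assay. Compound 3 (`O=C(N/N=C/c1ccc2nonc2c1)c1ccncc1`) reads > 400000 nM as a limit too.

Compound 4 (`Cc1c(C(=O)N/N=C/c2ccc(C(F)(F)F)cc2)no[n+]1[O-]`) carries trifluoromethyl in place of acetamido on an aromatic carbon, para to a large group (trifluoromethyl in place of acetamido on an aromatic carbon). Going by the values given here, no step between measured compounds is available to scale this change, so the expected step (a 1.2-fold lower number from compound 1 to compound 4 (0.07 log units; within the scatter)) stays within the scatter, with no direction favoured. A reading at the limit also stays possible for compound 4 (the limit of > 400000 nM in this assay, at which 2 of the 3 values shown sit). For compound 4 the estimated value is 200000 nM with an expected range from 80000 nM to 400000 nM in this series.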

Compound 4, half-maximal inhibitory concentration: > 400000 nM
Compound 4 gave a limit, no number; the forecaster's own chance of this, stated with the estimate: 35%; middle value at least 2.0-fold (0.30 log units) from the limit.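

Trifluoromethyl in place of acetamido on this aromatic carbon gives an at least 1.7-fold higher number from compound 1 to compound 4 (0.23 log units; that floor lies within the scatter) in this assay, the first step available at this position. The reading for compound 4 is a limit, not a number, so the step has a floor but no measured size, and the change brings no lower number. Acetamido remains the only group here with a true reading, while the series sits mostly at one limit: the limit of > 400000 nM in this assay, at which 3 of the 4 values shown sit.

On these data alone, how far compound 4 lies beyond that limit stays open. As far as these compounds go, whether an amine or a carboxylic acid at this position would give a true number also stays open.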